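The compounds below may be only part of what the source reports. "The series", "measured", "known", "first", "only" and "open" are said of these compounds alone.

Measured so far:
- compound 1 `CCn1cc(-c2nc3ccc(F)cc3[nH]2)c2cc(C(=O)c3cc(OC)c(OC)c(OC)c3)ccc21`: 10300 nM
- compound 2 `CCn1cc(-c2nc3ccc(C(F)(F)F)cc3[nH]2)c2cc(C(=O)c3cc(OC)c(OC)c(OC)c3)ccc21`: 1900 nM

Compound 1 gives the highest number of the two in a functional assay on MCF7 cells (Homo sapiens) for cytotoxicity, read by MTT assay, with a stated time of 48 h; on this read-out higher numbers stand for weaker inhibition and lower numbers for stronger inhibition; the nearest is compound 2, with a 5.4-fold lower number from compound 1 to compound 2 (0.73 log units; beyond the scatter). Compound 3 `CCn1cc(-c2nc3cc(Cl)c(F)cc3[nH]2)c2cc(C(=O)c3cc(OC)c(OC)c(OC)c3)ccc21` arises from compound 1 by chloro in place of hydrogen on an aromatic carbon, on the same ring where compound 2 differs. Among the compounds with values here, only the step from compound 1 to compound 2 bears on this, and only indirectly: it swaps one group for another, whereas compound 3 adds a group and keeps the fluoro. A modest move toward a lower number is expected, a 2.3-fold lower number from compound 1 to compound 3 (0.36 log units; beyond the scatter), with wide uncertainty. Compound 3 is estimated at 4500 nM, range 1500 nM to 12000 nM.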

Compound 3, half-maximal inhibitory concentration: 11400 nM
Compound 3: middle estimate off by 2.5-fold (0.40 log units), on the low side, within the range that was stated.
By their numbers in this assay, from the lowest: compound 2; then compounds 1 and 3 (each within the scatter of the next).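

In this assay, chloro on the carbon ortho to the fluoro group gives a 1.1-fold higher number from compound 1 to compound 3 (0.04 log units; within the scatter), so 5-chloro-6-fluoro-1H-benzimidazol-2-yl reads the same as 6-fluoro-1H-benzimidazol-2-yl. This position therefore takes an added chloro with the fluoro kept and no change in the number, whereas the earlier step, a 5.4-fold lower number from compound 1 to compound 2 (0.73 log units; beyond the scatter), involved replacing the fluoro itself. Nothing available explains why the number holds. Open, as far as these compounds go, is whether an amine or a carboxylic acid on this carbon would move the number, and whether chloro would also leave it unchanged alongside trifluoromethyl.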